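A few compounds are considered here, and "the series" means these few. Any claim that something is new, unique, unknown or untested is made for them only; others in the source may bear on it.

Compound 1 `CS(=O)(=O)c1ccc(-n2ccc3cnc(Nc4cnn(CCCCCCC(=O)NO)c4)nc32)cc1` gives 5.9 nM in an assay on isolated protein for inhibition of protein deacetylase HDAC6 (Homo sapiens), with a stated time of 60 min; on this read-out higher numbers stand for weaker inhibition and lower numbers for stronger inhibition. Compound 2 `CS(=O)(=O)c1ccc(-n2ccc3cnc(Nc4cnn(CCCCCC(=O)NO)c4)nc32)cc1` gives 10.8 nM in this assay, and compound 3 `O=C(CCCCCn1cc(Nc2ncc3ccn(Cc4ccccc4)c3n2)cn1)NO` gives 13.8 nM. Compound 3 thus stands highest of the three numbers: the nearest step is a 1.3-fold higher number from compound 2 to compound 3 (0.11 log units; within the scatter), whereas the two values of compound 3 and compound 1 lie apart beyond the scatter. Compound 4 `O=C(CCCCCCn1cc(Nc2ncc3ccn(Cc4ccccc4)c3n2)cn1)NO` carries (hydroxycarbamoyl)methyl in place of hydroxycarbamoyl on a saturated chain carbon, five bonds along the chain from an aromatic nitrogen. Among the measured compounds shown here, the reverse of this change is the only measured step that bears on it, a 1.8-fold higher number from compound 1 to compound 2 (0.26 log units; within the scatter), which stayed within the scatter. A lowering of similar small size, not beyond the scatter, is therefore expected in this assay. The expected step is a 1.8-fold lower number from compound 3 to compound 4 (0.25 log units; within the scatter). For compound 4 the estimate is 7.7 nM, with a range from 3.5 nM to 17 nM.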

Compound 4, half-maximal inhibitory concentration: 12.5 nM
For compound 4 the middle estimate is 1.6-fold (0.21 log units) below the measured one; low and high end bracket the measured number.
By their numbers in this assay, from the lowest: compounds 1, 2, 4 and 3 (each within the scatter of the next, the first and the last beyond it).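

On the benzyl core, (hydroxycarbamoyl)methyl in place of hydroxycarbamoyl stays within the scatter in this assay (a 1.1-fold lower number from compound 3 to compound 4 (0.04 log units; within the scatter)), so the chain change now reads alike on two cores: the same change on two cores in this assay, a 1.8-fold higher number (0.26 log units; within the scatter) from compound 1 to compound 2 and a 1.1-fold higher number (0.04 log units; within the scatter) from compound 4 to compound 3, 1.7-fold (0.22 log units) apart, within the scatter of two such steps.
Among the compounds shown here, with the chain of compound 4 held, benzyl in place of 4-(methylsulfonyl)phenyl on the aromatic nitrogen gives a modest step (a 2.1-fold higher number from compound 1 to compound 4 (0.33 log units; beyond the scatter)), the first of this change beyond the scatter, yet it does not clearly differ from the earlier one: the same change on two cores in this assay, a 1.3-fold higher number (0.11 log units; within the scatter) from compound 2 to compound 3 and a 2.1-fold higher number (0.33 log units; beyond the scatter) from compound 1 to compound 4, 1.7-fold (0.22 log units) apart, within the scatter of two such steps.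
As far as these compounds go, a longer chain and a carboxylic acid in place of hydroxycarbamoyl remain open, as does an amine on the group at the aromatic nitrogen.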